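The source may report more compounds than this note shows. Statements on the series, on what has been measured and on what is new or still open speak of the compounds shown alone.

Measured compounds:
Compound 1, `CS(=O)(=O)Nc1ccc(-c2nc3ccccc3o2)cc1`: in an assay on isolated protein for inhibition of malate dehydrogenase, mitochondrial (Sus scrofa), with stated times of 45 min and 30 min (on this read-out lower numbers stand for stronger inhibition and higher numbers for weaker inhibition), compound 1 gives > 63000 nM, a limit of the assay rather than a number.
Compound 2, `O=S(=O)(Nc1ccc2oc(-c3ccccc3)nc2c1)c1ccccc1F`: compound 2 gives > 63000 nM, also a limit.
Compound 3, `O=S(=O)(Nc1ccc2oc(-c3ccccc3)nc2c1)c1cccs1`: compound 3 gives > 63000 nM, again a limit.

Compound 1 thus sits at the limit of > 63000 nM in this assay, at which 3 of the 3 values shown sit, so no true number is known for it. The change to compound 4 `O=S(=O)(Nc1ccc(-c2nc3ccccc3o2)cc1)c1ccc(Cl)cc1` is 4-chlorophenyl in place of methyl on a sulfonyl sulfur. Within the data shown here, the one measured step, a step that the two limits leave unreadable from compound 2 to compound 3, runs between two limits and gives no readable size to carry over. Nothing among these compounds shows this read-out moving off the limit. The step from compound 1 to compound 4 is therefore expected to be a number no higher from compound 1 to compound 4 (the limit leaves the size open), with no movement beyond the scatter. Compound 4 is estimated at 63000 nM, between 20000 nM and 200000 nM.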

Compound 4, half-maximal inhibitory concentration: > 63000 nM
Compound 4 was reported as a limit; the forecaster's own chance of this, stated with the estimate: 75%; the middle value sits exactly at the limit.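

No size can be read for the change between compound 1 and compound 4, since both values are limits rather than numbers: the limit of > 63000 nM in this assay, at which 4 of the 4 values shown sit. The compounds shown leave open how strongly any of them truly inhibits, and which change would bring a value off this limit.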